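Aryl substituent variation at the biaryl position, binding read-out

This account rests on a few compounds, and the source may have more. Where it says the series, first, only, none or still open, it means among the compounds named here.

Measured so far:
Compound 1 `CCCS(=O)(=O)Nc1ccc(F)c(C(=O)c2n[nH]c3ncc(-c4ccc(C)cc4)cc23)c1F` gives 5.4% in an assay for binding affinity to dual specificity mitogen-activated protein kinase kinase 4 (Homo sapiens), read by KINOMEscan, tested at 100 nM; on this read-out higher numbers stand for a weaker effect at the one concentration tested and lower numbers for a stronger effect.
Compound 2 `CCCS(=O)(=O)Nc1ccc(F)c(C(=O)c2n[nH]c3ncc(-c4ccc(N)cc4)cc23)c1F` gives 0.1% in this assay.
Compound 3 `CCCS(=O)(=O)Nc1ccc(F)c(C(=O)c2n[nH]c3ncc(-c4ccc(C(C)(C)C)cc4)cc23)c1F` gives 46% in this assay.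

Compound 3 stands highest of the three in this assay, beyond the scatter from both others: a number 40.6 percentage points higher from compound 1 to compound 3 (beyond the scatter) and a number 45.9 percentage points higher from compound 2 to compound 3 (beyond the scatter), whereas a number 5.3 percentage points lower from compound 1 to compound 2 (within the scatter). Compound 4 `CCCS(=O)(=O)Nc1ccc(F)c(C(=O)c2n[nH]c3ncc(-c4ccc(F)cc4C)cc23)c1F` differs from compound 3 as follows: 4-fluoro-2-methylphenyl in place of 4-(tert-butyl)phenyl on an aromatic carbon. The two steps toward compound 3 both bear on this: replacing methyl or amino by tert-butyl raised the number by a large amount, so moving from tert-butyl back to a smaller group is expected to lower it. For the measured compounds named here, no measured compound carries the 4-fluoro-2-methylphenyl group, so the size is uncertain. Compound 4 is therefore expected to give 12% in this assay, range 2% to 40%. The expected step is a number 34 percentage points lower from compound 3 to compound 4 (beyond the scatter).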

Compound 4, a percentage reported as activity, at one concentration (the size of the read-out at that concentration, not a potency): 14%
The estimate for compound 4 lay 2 percentage points below the measured number; the measured number falls inside the stated range.
By their numbers in this assay, from the lowest: compounds 2, 1 and 4 (each within the scatter of the next, the first and the last beyond it); then compound 3.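

In this assay the 4-fluoro-2-methylphenyl group stands well apart from 4-(tert-butyl)phenyl (a number 32 percentage points lower from compound 3 to compound 4 (beyond the scatter)) and modestly apart from 4-aminophenyl (a number 13.9 percentage points higher from compound 2 to compound 4 (beyond the scatter)), but cannot be told from 4-methylphenyl (a number 8.6 percentage points higher from compound 1 to compound 4 (within the scatter)). A phenyl ring with two substituents at this position therefore reads like the 4-methylphenyl of compound 1, and compound 3 alone stands above all the others. Nothing on hand explains these steps.

Left open is whether the fluoro or the methyl of compound 4 sets its number, and how a carboxylic acid or a morpholine on this phenyl ring would read.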